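Methyl for Methoxy on the Aromatic Carbon

The source may report more compounds than this note shows. Statements on the series, on what has been measured and on what is new or still open speak of the compounds shown alone.

Compound 2 `CCn1nc(C)c2c1CCN(C(C(=O)NC)c1ccccc1)C2CCc1ccc(OC)cc1` stands highest of the three measured numbers in a functional assay on CHO cells for antagonist activity at Orexin/Hypocretin receptor type 1 (Homo sapiens), read by FLIPR and calcium flux (on this read-out higher numbers stand for weaker inhibition and lower numbers for stronger inhibition), where compound 2 gives 10000 nM. Its nearest neighbour is compound 3 `CCn1nc(C)c2c1CCN([C@@H](C(=O)NC)c1ccccc1)[C@@H]2CCc1ccc(C(C)C)cc1`, which in this assay gives 1920 nM; furthest away is compound 1 `CCn1nc(C)c2c1CCN([C@@H](C(=O)NC)c1ccccc1)[C@H]2CCc1ccc(C(C)C)cc1`, which in this assay gives 161 nM. Compounds 1 and 3 carry an isopropyl group where compound 2 carries methoxy, and both are drawn with defined configuration, whereas compound 2 is not.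

Among the compounds with values here, the only step measured between a pair differing in one place is a 12-fold higher number from compound 1 to compound 3 (1.08 log units; beyond the scatter). It rests on the fact that compounds 1 and 3 differ only in the configuration as drawn and so says nothing about a change of the group on the aromatic carbon.

Compound 4 `CCn1nc(C)c2c1CCN(C(C(=O)NC)c1ccccc1)C2CCc1ccc(C)cc1` differs from compound 2 by methyl in place of methoxy on an aromatic carbon. Within the data shown here, no measured step covers this kind of change. What can be said is that compounds 1 and 3, which carry isopropyl, give lower numbers than compound 2 with its methoxy, but they also differ from compound 2 in configuration, so that comparison is not clean. The step expected in this assay is therefore a modest fall, a 2.9-fold lower number from compound 2 to compound 4 (0.46 log units; beyond the scatter), with wide uncertainty. Compound 4 is estimated at 3500 nM, expected to lie between 900 nM and 10000 nM.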

Compound 4, half-maximal inhibitory concentration: 108 nM
For compound 4 the middle estimate is 32-fold (1.51 log units) above the measured one; the measured number lies below the stated range.
By their numbers in this assay, from the lowest: compounds 4 and 1 (each within the scatter of the next); then compound 3; then compound 2.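

In this assay, the place on the aromatic carbon, para to a large group, turns out to matter a great deal: exchanging methoxy for methyl gives a 93-fold lower number from compound 2 to compound 4 (1.97 log units; beyond the scatter). Within the data shown here, this is the first measured change of a group in this set, and it shows that replacing 2-(4-methoxyphenyl)ethyl with 2-(4-methylphenyl)ethyl, with the rest of the molecule unchanged, is enough to produce a large step beyond the scatter. Compounds 2 and 4 are both drawn without defined configuration, so this step stands apart from the only earlier one, a 12-fold higher number from compound 1 to compound 3 (1.08 log units; beyond the scatter), which concerned configuration alone: the fact that compounds 1 and 3 differ only in the configuration as drawn.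

The compounds shown leave open how much of the number of compound 4 belongs to each configuration, given that the pair of compounds 1 and 3 shows configuration alone can produce a large step. They also leave open whether the step follows the loss of the oxygen or the presence of the methyl, and where a hydrogen, an ethyl group, a chlorine atom or an amine at the same place would fall.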